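The compounds below may be only part of what the source reports. "The series", "measured", "known", "first", "only" and "open" are said of these compounds alone.

Compound 3 `CC(C)(C)N(NC(=O)c1ccccc1Cl)C(=O)c1ccccc1Cl` gives 331 nM in an assay on cells for agonist activity at ecdysone receptor (Bombyx mori), read by a luciferase reporter, with a stated time of 24 h (on this read-out lower numbers stand for an effect already at smaller amounts and higher numbers for an effect only at larger amounts of compound), the second highest of the three numbers seen. Its nearest neighbour is compound 1 `CCc1ccccc1C(=O)N(NC(=O)c1ccccc1)C(C)(C)C`, which gives 589 nM in this assay, a gap that lies within the scatter; furthest from it is compound 2 `CC(C)(C)N(NC(=O)c1ccccc1)C(=O)c1ccc(Cl)cc1Cl`, which gives 117 nM in this assay, a gap beyond the scatter. Compound 4 `CC(C)(C)N(NC(=O)c1cccc(C#N)c1)C(=O)c1ccccc1Cl` differs from compound 3 by 3-cyanophenyl in place of 2-chlorophenyl on a carbonyl carbon. Among the compounds with values here, the only step measured between single-point changes, a 5.0-fold lower number from compound 1 to compound 2 (0.70 log units; beyond the scatter), concerns the other carbonyl carbon, the one bearing the tert-butyl-substituted nitrogen, and so speaks to a different position; no measured pair isolates a change on the carbonyl carbon next to the amide-type nitrogen, and none exchanges a chlorine for a nitrile. The expectation for compound 4 therefore rests on the modest size of that one step and is a small move, a 1.2-fold lower number from compound 3 to compound 4 (0.07 log units; within the scatter), not beyond the scatter in either direction. Compound 4 is thus estimated to give 280 nM in this assay, with a range from 90 nM to 900 nM.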

Compound 4, half-maximal effective concentration: 955 nM
Estimate against measurement, compound 4: 3.4-fold (0.53 log units) below; the measured number lies above the stated range.
By their numbers in this assay, from the lowest: compound 2; then compounds 3, 1 and 4 (each within the scatter of the next, the first and the last beyond it).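

In this assay, this is the first single change shown on the carbonyl carbon whose other neighbour is the amide-type nitrogen, and it shows that this place is not indifferent to what it carries: a 2.9-fold higher number from compound 3 to compound 4 (0.46 log units; beyond the scatter) follows when 3-cyanophenyl enters in place of 2-chlorophenyl. The earlier step at the other carbonyl carbon went to a lower number, so this is the first single change shown that goes to a higher one, though it too is modest. Nothing measured here accounts for the move.

The exchange removes a chlorine and adds a nitrile on the ring in one step, so the compounds shown cannot separate the two. They also leave open how a methoxy group or an amine would fare on this ring.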